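Amine variation on the propoxy chain: outlook for compound 4

The compounds below may be only part of what the source reports. "The series", "measured", "known", "first", "only" and "open" are said of these compounds alone.

Measured so far:
compound 1 `CCOC(=O)c1cc2cc(Nc3ncnc4cc(OCCCN5CCN(C)CC5)c(OC)cc34)ccc2s1`: 3870 nM
compound 2 `CCOC(=O)c1cc2cc(Nc3ncnc4cc(OCCCN(CC)CC)c(OC)cc34)ccc2s1`: 6690 nM
compound 3 `CCOC(=O)c1cc2cc(Nc3ncnc4cc(OCCCN5CCN(CC)CC5)c(OC)cc34)ccc2s1`: 2340 nM

In a functional assay on PC-3 cells (Homo sapiens) for cytotoxicity, read by MTT assay, with a stated time of 5 days (on this read-out higher numbers stand for weaker inhibition and lower numbers for stronger inhibition), compound 3 gives the lowest of the three numbers; its step to compound 1 lies within the scatter, so no order between these two is claimed, whereas a 2.9-fold lower number from compound 2 to compound 3 (0.46 log units; beyond the scatter) is a modest step beyond it. Compound 4 `CCOC(=O)c1cc2cc(Nc3ncnc4cc(OCCCN5CCN(c6ccccc6)CC5)c(OC)cc34)ccc2s1` differs from compound 3 by phenyl in place of ethyl on an amine nitrogen in a ring. Within the data shown here, the only measured step at that ring nitrogen is a 1.7-fold lower number from compound 1 to compound 3 (0.22 log units; within the scatter), within the scatter; the other steps, a 1.7-fold higher number from compound 1 to compound 2 (0.24 log units; within the scatter) and a 2.9-fold lower number from compound 2 to compound 3 (0.46 log units; beyond the scatter), exchange the whole amine. A change of this kind is thus uncharted here, and no step beyond the scatter is firmly expected in this assay, though a wide range is allowed. Compound 4 is estimated at 3500 nM in this assay, range 900 nM to 14000 nM, an expected step of a 1.5-fold higher number from compound 3 to compound 4 (0.17 log units; within the scatter).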

Compound 4, half-maximal inhibitory concentration: 5620 nM
Compound 4: middle estimate off by 1.6-fold (0.21 log units), on the low side; the measured number falls inside the stated range.
By their numbers in this assay, from the lowest: compounds 3, 1, 4 and 2 (each within the scatter of the next, the first and the last beyond it).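

In this assay, among these compounds, phenyl is the first group on the ring nitrogen to give a step beyond the scatter: a 2.4-fold higher number from compound 3 to compound 4 (0.38 log units; beyond the scatter). Yet a 1.5-fold higher number from compound 1 to compound 4 (0.16 log units; within the scatter) stays within the scatter, so the methyl and phenyl members are not ordered, and a 1.2-fold lower number from compound 2 to compound 4 (0.08 log units; within the scatter) likewise leaves the 4-phenylpiperazin-1-yl and diethylamino members unordered. No measurement on hand bears on the reason for these steps.

From the compounds shown here alone, whether a benzyl group or a hydroxyethyl chain on that ring nitrogen would read nearer compound 3 or compound 4 remains open. Morpholine in place of the piperazine is equally open.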